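Swapping the Acetamido Pyrrolidine for a Spiro Diamine

This account rests on a few compounds, and the source may have more. Where it says the series, first, only, none or still open, it means among the compounds named here.

Compound 3 `CC(=O)NC1CCN(c2ccc3cc(NC(=O)CCc4ccc(C(F)(F)F)cc4)ccc3n2)C1` stands second highest of the three numbers in an assay on isolated protein for displacement of a labelled ligand from melanin-concentrating hormone receptor 1 (Homo sapiens) (a lower number here means a stronger inhibitor, a higher number a weaker inhibitor), giving 5 nM. Compound 1 `O=C(CCc1ccc(C(F)(F)F)cc1)Nc1ccc2nc(N3CCC(c4ccccc4)C3)ccc2c1` gives 25 nM, and compound 2 `CC(C)C(=O)NC1CCN(c2ccc3cc(NC(=O)CCc4ccc(C(F)(F)F)cc4)ccc3n2)C1` gives 1 nM. The steps closest to the present change are a 5.0-fold lower number from compound 1 to compound 3 (0.70 log units; beyond the scatter) and a 5.0-fold higher number from compound 2 to compound 3 (0.70 log units; beyond the scatter), both modest; the larger one is a 25-fold lower number from compound 1 to compound 2 (1.40 log units; beyond the scatter). Compound 4 `O=C(CCc1ccc(C(F)(F)F)cc1)Nc1ccc2nc(N3CCC4(CCNC4)C3)ccc2c1` carries the change (a group of 9 heavy atoms (7 carbon, 2 nitrogen; 2 five-membered non-aromatic rings with 1 hetero atom each) in place of a group of 9 heavy atoms (6 carbon, 2 nitrogen, 1 oxygen; one five-membered non-aromatic ring with 1 hetero atom), on an aromatic carbon), with the 3-acetamidopyrrolidin-1-yl group leaving and a group without a carbonyl entering. Within the data shown here, no measured step removes the carbonyl of the acetamido while keeping a hydrogen-bond donor, so the known steps give only the scale, not the direction. A modest weakening is expected for compound 4, a 4.0-fold higher number from compound 3 to compound 4 (0.60 log units; beyond the scatter). Compound 4 is therefore estimated at 20 nM, within 4 nM to 100 nM.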

Compound 4, half-maximal inhibitory concentration: 0.5 nM
Compound 4: the middle estimate sits 40-fold (1.60 log units) above what was measured, and the stated range ends above it.
By their numbers in this assay, from the lowest: compounds 4 and 2 (each within the scatter of the next); then compound 3; then compound 1.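

In this assay, an amide carbonyl on this group is not needed for a low number at this aromatic carbon: the entering group has none, and the step is a 10-fold lower number from compound 3 to compound 4 (1.00 log units; beyond the scatter) in its favour. Against the isopropyl amide the step is a 2.0-fold lower number from compound 2 to compound 4 (0.30 log units; within the scatter) and no gain, while against the phenyl group it is a 50-fold lower number from compound 1 to compound 4 (1.70 log units; beyond the scatter) and a large one. Nothing available explains these steps.

Going by these compounds, the carbonyl and the ring count change together here, so their separate shares stay open. So does the effect of a methyl or acetyl group on the free ring amine of compound 4.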